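Removing tert-butoxycarbonyl from compound 2

The source may hold more compounds than are shown below. What is called first, only, known or untested is meant among the compounds shown, and "the series" means these compounds.

Three compounds that share one core and differ only in the phenyl group on an amide-type nitrogen have been tested in a functional assay on K562 cells (Homo sapiens) for inhibition, read by MTT assay, with a stated time of 48 h; on this read-out higher numbers stand for weaker inhibition and lower numbers for stronger inhibition. Compound 1 `CC(C)(C)OC(=O)N1C[C@@H](n2cc(-c3ccc4nc(N)sc4n3)nn2)C[C@H]1C(=O)Nc1ccc(Cl)c(C(F)(F)F)c1` gives 10900 nM, compound 2 `CC(C)(C)OC(=O)N1C[C@@H](n2cc(-c3ccc4nc(N)sc4n3)nn2)C[C@H]1C(=O)Nc1ccc(Cl)cc1Cl` gives 8940 nM, and compound 3 `CC(C)(C)OC(=O)N1C[C@@H](n2cc(-c3ccc4nc(N)sc4n3)nn2)C[C@H]1C(=O)Nc1ccc(Br)cc1` gives 29200 nM. Compound 2 thus sits at the low end of these numbers, alongside compound 1. The step between those two is a 1.2-fold lower number from compound 1 to compound 2 (0.09 log units; within the scatter). The third number lies further off, with a 2.7-fold higher number from compound 1 to compound 3 (0.43 log units; beyond the scatter) and a 3.3-fold higher number from compound 2 to compound 3 (0.51 log units; beyond the scatter).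

Compound 4 `Nc1nc2ccc(-c3cn([C@@H]4CN[C@H](C(=O)Nc5ccc(Cl)cc5Cl)C4)nn3)nc2s1` changes another part of compound 2: hydrogen in place of tert-butoxycarbonyl on an amine nitrogen in a ring. This puts hydrogen in place of tert-butoxycarbonyl on an amine nitrogen in a ring. For the measured compounds named here, no measured step touches this group, so the phenyl swaps give only a rough scale of modest moves in this assay and no direction. A modest rise is therefore a tentative expectation, and the estimated change is a 2.2-fold higher number from compound 2 to compound 4 (0.35 log units; beyond the scatter). For compound 4 the estimate is 20000 nM, with an expected range from 5000 nM to 70000 nM.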

Compound 4, half-maximal inhibitory concentration: 24500 nM
Beside the measured number, compound 4's estimate is 1.2-fold (0.09 log units) below it; the measured number falls inside the stated range.
By their numbers in this assay, from the lowest: compounds 2 and 1 (each within the scatter of the next); then compounds 4 and 3 (each within the scatter of the next).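

In this assay, for the compounds shown here, the first measured change at this amine nitrogen gives a 2.7-fold higher number from compound 2 to compound 4 (0.44 log units; beyond the scatter), so replacing tert-butoxycarbonyl with hydrogen moves the number towards weaker inhibition, a direction the phenyl swaps could not show. Losing all 7 heavy atoms of the group does not abolish the effect, since compound 4 still gives a measured number of 24500 nM. Nothing measured here explains why the number rises.

On these data alone, this step rests on the 2,4-dichlorophenyl compounds alone, so it remains open whether the same change would shift the number similarly with the 4-bromophenyl or 4-chloro-3-(trifluoromethyl)phenyl groups on the amide. Also open, as far as these compounds go, is where a methyl group, an acetyl group or a longer carbon chain on this nitrogen would fall relative to hydrogen and tert-butoxycarbonyl.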